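The compounds below may be only part of what the source reports. "The series", "measured", "known", "first", "only" and "open" are said of these compounds alone.

Compound 1 `NC(=O)[C@@H](CCC(F)(F)F)N(CC12CC(c3ncon3)(C1)C2)S(=O)(=O)c1ccc(Cl)cc1`: 19.3 10^-6 cm/s
Compound 2 `N#CCCCN([C@H](CCC(F)(F)F)C(N)=O)S(=O)(=O)c1ccc(Cl)cc1`: 27.6 10^-6 cm/s
Compound 3 `N#C[C@H]1CC[C@H](CN([C@H](CCC(F)(F)F)C(N)=O)S(=O)(=O)c2ccc(Cl)cc2)CC1`: 15.7 10^-6 cm/s; 14.6 10^-6 cm/s (2 entries)

In an ADME assay on MDCKII-LE cells (Canis lupus familiaris) for permeability (a higher number here means that the compound crosses the layer faster, a lower number that the compound crosses the layer more slowly), compound 2 gives 27.6 10^-6 cm/s, and the step of a 1.4-fold higher number from compound 1 to compound 2 (0.16 log units; within the scatter) shows that compound 1 and compound 2 lie within the usual scatter of each other. Compound 3 has repeated entries, (the several entries of compound 3 in this assay, 15.7 10^-6 cm/s; 14.6 10^-6 cm/s (2 entries)), which sit close together. Compound 4 `NC(=O)[C@@H](CCC(F)(F)F)N(C[C@H]1C[C@@H](c2ncon2)C1)S(=O)(=O)c1ccc(Cl)cc1` is not yet measured; it differs from compound 2 by 3-(1,2,4-oxadiazol-3-yl)cyclobutyl in place of 2-cyanoethyl on a saturated chain carbon bound to a sulfonamide nitrogen. For the measured compounds named here, the only measured step that bears on this change is a 1.4-fold higher number from compound 1 to compound 2 (0.16 log units; within the scatter), which replaced a larger ring-bearing group with a short chain and moved the number only within the scatter. Going the opposite way, compound 4 is expected to change by a 1.5-fold lower number from compound 2 to compound 4 (0.16 log units; within the scatter), not beyond the scatter. The estimated value for compound 4 in this assay is 19 10^-6 cm/s, between 11 10^-6 cm/s and 32 10^-6 cm/s.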

Compound 4, apparent permeability: 14.1 10^-6 cm/s
Compound 4: the middle estimate sits 1.3-fold (0.13 log units) above what was measured; low and high end bracket the measured number.
By their numbers in this assay, from the lowest: compounds 4, 1 and 2 (each within the scatter of the next).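

In this assay, putting 3-(1,2,4-oxadiazol-3-yl)cyclobutyl in place of 2-cyanoethyl gives a 2.0-fold lower number from compound 2 to compound 4 (0.29 log units; within the scatter), so even this larger group on a saturated chain carbon bound to a sulfonamide nitrogen stays within the scatter of the short chain. The group of compound 1 and the group of compound 4 also cannot be told apart here: a 1.4-fold lower number from compound 1 to compound 4 (0.14 log units; within the scatter). Nothing measured here offers a reason for these numbers. Going by these compounds, whether an amine or a carboxylic acid in this place would give a step beyond the scatter remains open.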